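The source may hold more compounds than are shown below. What is called first, only, known or untested is meant among the compounds shown, and "the series" means these compounds.

Measured so far:
compound 1 `Cc1cc(O)c(C2=NN(c3ccc(S(N)(=O)=O)cc3)C(c3ccccc3O)C2)cc1Cl` — 1330 nM
compound 2 `Cc1cc(O)c(C2=NN(c3ccc(S(N)(=O)=O)cc3)C(c3ccccc3Cl)C2)cc1Cl` — 1580 nM

Among the measured compounds shown here, in a functional assay on PC-3 cells (Homo sapiens) for antiproliferative activity, with a stated time of 48 h (a lower number here means a stronger inhibitor of growth, a higher number a weaker inhibitor of growth), compound 2 stands alongside compound 1, the only other member: a 1.2-fold higher number from compound 1 to compound 2 (0.07 log units; within the scatter). Compound 3 `Cc1cc(O)c(C2=NN(c3ccc(S(N)(=O)=O)cc3)C(/C=C/c3ccccc3)C2)cc1Cl` carries the change (2-phenylethenyl in place of 2-chlorophenyl on a saturated ring carbon). For the measured compounds named here, no measured step covers an exchange of this kind; the single step of a 1.2-fold higher number from compound 1 to compound 2 (0.07 log units; within the scatter) swaps one substituent on an aromatic carbon and leaves the ring in place, so it gives no guide to removing the ring itself. With nothing in the series arguing for a shift, compound 3 is expected to land near compound 2, a 1.0-fold higher number from compound 2 to compound 3 (0.01 log units; within the scatter), but with a wide spread. The estimate for compound 3 in this assay is 1600 nM, range 500 nM to 5000 nM.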

Compound 3, concentration for 50% growth inhibition: 3150 nM
The estimate for compound 3 lay 2.0-fold (0.29 log units) below the measured number; the measured number falls inside the stated range.
By their numbers in this assay, from the lowest: compounds 1, 2 and 3 (each within the scatter of the next, the first and the last beyond it).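

The saturated ring carbon next to the ring nitrogen accepts more than a substituent swap on its aryl ring: in this assay, 2-phenylethenyl in place of 2-chlorophenyl stays within the scatter (a 2.0-fold higher number from compound 2 to compound 3 (0.30 log units; within the scatter)). Against 2-hydroxyphenyl, the same group gives the first step in the series beyond the scatter, a modest one (a 2.4-fold higher number from compound 1 to compound 3 (0.37 log units; beyond the scatter)). No measurement in hand accounts for either step.

Still open, going by these compounds, is whether the double bond matters, which 2-phenylethyl at this carbon would test. Also open, on these data alone, is how a pyridyl ring or a small alkyl chain would read there.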